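This account rests on a few compounds, and the source may have more. Where it says the series, first, only, none or still open, it means among the compounds named here.

Compound 1, `O=C(Nc1ccncc1)Nc1ccccc1Br`, gives 100 mg/kg in a functional assay on the whole organism with Mus musculus as the target, in the maximal electroshock model, with a stated time of 30 min; a lower number here means that less compound is needed, a higher number that more compound is needed for the effect.
Compound 2, `N#Cc1ccccc1NC(=O)Nc1ccncc1`, gives only a limit of the assay, > 300 mg/kg in this assay.

Compound 1 stands at the only number shown in this set. Compound 2 returns a limit rather than a number and sits at the limit of > 300 mg/kg in this assay, at which 1 of the 2 values shown sits. Compound 3, `O=C(Nc1ccncc1)Nc1ccccc1O`, has not yet been measured in this assay. It differs from compound 1 in one place: hydroxy in place of bromo on an aromatic carbon. Within the data shown here, the only measured step that touches the same position is an at least 3.0-fold higher number from compound 1 to compound 2 (0.47 log units; beyond the scatter), and it too removes the bromo group, though it puts a cyano rather than a hydroxy group in its place. On that single precedent, a move away from bromo at this position has gone toward a higher number, and a step of that kind is expected here as well; its size is uncertain, as the full extent of the measured step is not known. Compound 3 is therefore expected to give 200 mg/kg, within a range from 80 mg/kg to 400 mg/kg, which would mean an expected step of a 2.0-fold higher number from compound 1 to compound 3 (0.30 log units; within the scatter), with a fair chance that only a limit is returned.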

Compound 3, minimum effective dose: > 300 mg/kg
Compound 3 was reported as a limit (the forecaster's own chance of this, stated with the estimate: 45%); at least 1.5-fold (0.17 log units) between middle value and limit.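

In this assay, the step of an at least 3.0-fold higher number from compound 1 to compound 3 (0.47 log units; beyond the scatter) gives this position a second replacement of the bromo group that moves the same way as the first, so the earlier direction no longer rests on the cyano group alone. Hydroxy brings one hydrogen-bond donor and one hydrogen-bond acceptor where bromo carried neither, yet this change, too, ends without a number, and among the compounds shown only the bromo group at this place returns one. Compound 2 and compound 3 share the same limit of the assay, so the step between them cannot be read and the two replacements cannot be ranked against each other: the limit of > 300 mg/kg in this assay, at which 2 of the 3 values shown sit.

Going by these compounds, it remains open whether a chloro or fluoro group, or a methyl or methoxy group, in place of bromo would return a number, and whether that number would stand apart from the value of compound 1 by more than the usual scatter. On these data alone, it is also open how far compound 2 and compound 3 lie past their limit, and whether the same changes would act alike elsewhere on the ring, as all three compounds carry their group at this one place.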